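This account rests on a few compounds, and the source may have more. Where it says the series, first, only, none or still open, it means among the compounds named here.

Measured in a functional assay on U2OS cells (Homo sapiens) for cytotoxicity, read by MTT assay, with a stated time of 48 h (on this read-out lower numbers stand for stronger inhibition and higher numbers for weaker inhibition), as follows
compound 1 `Fc1ccc(Nc2nc(-c3cccc(F)c3)nc3ccc(F)cc23)cc1` gives > 50000 nM (a limit)
compound 2 `Fc1cccc(-c2nc(Nc3cccc(Br)c3)c3cc(F)ccc3n2)c1` gives > 50000 nM (a limit)
compound 3 `Nc1cccc(Nc2nc(-c3cccc(F)c3)nc3ccc(F)cc23)c1` gives 49700 nM (a number)

Within the data shown here, compound 3 holds the only true number in this set, with 49700 nM as its reading in this assay here. The other two values are limits, and the limit of > 50000 nM in this assay, at which 2 of the 3 values shown sit, is all they give.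

Compound 4 `Cc1cccc(Nc2nc(-c3cccc(F)c3)nc3ccc(F)cc23)c1` carries methyl in place of amino on an aromatic carbon, meta to a large group, and methyl in place of amino on an aromatic carbon is the counted difference from compound 3.

Two measured steps end at compound 3, namely a number no higher from compound 2 to compound 3 (the limit leaves the size open) and a number no higher from compound 1 to compound 3 (the limit leaves the size open), and neither has a readable size. The remaining one, a step that the two limits leave unreadable from compound 1 to compound 2, is no more informative. Where compound 3 has amino, compound 2 has bromo, and its value of > 50000 nM is a limit. That is the nearest comparison for replacing the amino group, and it offers no sign of a gain in strength.

No step beyond the scatter is therefore expected, and the estimated move is a 1.0-fold higher number from compound 3 to compound 4 (0.00 log units; within the scatter) in this read-out. The expected value for compound 4 is 50000 nM, with an estimated range from 30000 nM to 90000 nM in this assay when read.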

Compound 4, half-maximal inhibitory concentration: > 50000 nM
Compound 4 gave a limit, no number; the forecaster's own chance of this, stated with the estimate: 65%; the middle value lies on the limit itself.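

In this assay compound 4 gives > 50000 nM, which is a limit and not a number. Methyl in place of amino on this aromatic carbon, meta to a large group, is read only by direction, as a number no lower from compound 3 to compound 4 (the limit leaves the size open), and the steps linking compound 4 to compound 1 and compound 2 cannot be read. At this place, amino in compound 3 is now the only one of the three groups shown to give a number, while methyl in compound 4 and bromo in compound 2 both give limits, so neither replacement shows any gain in strength, and most of the set sits at one limit: the limit of > 50000 nM in this assay, at which 3 of the 4 values shown sit.

Going by these compounds, whether a hydroxyl, a dimethylamino or an aminomethyl group at this place would give a number in this assay, and how it would compare with compound 3, stays open. On these data alone, the sizes of any gaps among compound 1, compound 2 and compound 4 also stay open.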